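Replacing a Fluorophenyl Sulfone with a Bicyclic Heterocycle

A few compounds are considered here, and "the series" means these few. Any claim that something is new, unique, unknown or untested is made for them only; others in the source may bear on it.

Measured so far:
compound 1, `CN1CCC(n2cc(S(=O)(=O)c3ccccc3Cl)c3cccnc32)C1`, gives 91 nM in a functional assay on HeLa cells for antagonist activity at 5-hydroxytryptamine receptor 6 (Homo sapiens), read by cAMP accumulation and immunoassay; a lower number here means a stronger inhibitor, a higher number a weaker inhibitor
compound 2, `CCN1CCC(n2cc(S(=O)(=O)c3cccc(F)c3)c3cccnc32)C1`, gives 132 nM in this assay

Compound 2 carries the higher of the two numbers, yet its gap to compound 1 lies within the scatter, so the two cannot be told apart. Compound 3, `CCN1CCC(n2cc(S(=O)(=O)C3=C(Cl)NC4SC=CN34)c3cccnc32)C1`, is not yet measured. It differs from compound 2 by a group of 9 heavy atoms (5 carbon, 2 nitrogen, 1 sulfur, 1 chlorine; 2 five-membered non-aromatic rings with 2 hetero atoms each) in place of a group of 7 heavy atoms (6 carbon, 1 fluorine; one six-membered aromatic ring of carbon only), on a sulfonyl sulfur. Within the data shown here, no measured pair shows what such an exchange does, so the expectation rests on compound 2 alone. Because compound 2 gives 132 nM, that value is the starting point, and a weaker result is expected since an aromatic ring of carbon only gives way to a saturated, donor-bearing ring pair. The expected step is a 2.7-fold higher number from compound 2 to compound 3 (0.42 log units; beyond the scatter), a loss beyond the scatter. For compound 3 the estimated value in this assay is 350 nM, within 70 nM to 2000 nM.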

Compound 3, half-maximal inhibitory concentration: 10 nM
Compound 3: middle estimate off by 35-fold (1.54 log units), on the high side; the whole stated range lies above it.
By their numbers in this assay, from the lowest: compound 3; then compounds 1 and 2 (each within the scatter of the next).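

On the sulfonyl sulfur, the 3-fluorophenyl group can give way to a very different group, a pair of five-membered non-aromatic rings carrying chlorine, sulfur and nitrogen. In this assay this exchange gives a 13-fold lower number from compound 2 to compound 3 (1.12 log units; beyond the scatter), a large gain in inhibition that the two earlier compounds, whose values cannot be told apart, gave no hint of. The result shows that this position accepts a non-aromatic ring pair with a hydrogen-bond donor, but nothing available here explains why the number falls.

The compounds shown do not separate the contributions of the chlorine, the sulfur and the ring nitrogen bearing the hydrogen. Replacing that chlorine with a methyl group or a plain hydrogen would begin to show whether the chlorine matters to the gain.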